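A few compounds are considered here, and "the series" means these few. Any claim that something is new, unique, unknown or untested is made for them only; others in the source may bear on it.

Compound 1 `N#CC1=C(N)N(c2ccc(S(N)(=O)=O)cc2)C2=C(C(=O)CCC2)C1c1ccc(Cl)cc1Cl` carries a free amino group on the shared core. In a functional assay on Ehrlich cells (Mus musculus) for cytotoxicity, read by trypan blue exclusion, with a stated time of 2 h, tested at 100 ug/mL (on this read-out lower numbers stand for a weaker effect and higher numbers for a stronger effect at the one concentration tested), compound 1 gives 95%, the highest of the three numbers measured. Compound 2 `N#CC1=C(NC(=O)C2CC2)N(c2ccc(S(N)(=O)=O)cc2)C2=C(C(=O)CCC2)C1c1ccc(Cl)cc1Cl` gives 60% in this assay, and compound 3 `N#CC1=C(/N=C/c2ccc([N+](=O)[O-])cc2[N+](=O)[O-])N(c2ccc(S(N)(=O)=O)cc2)C2=C(C(=O)CCC2)C1c1ccc(Cl)cc1Cl` gives 20%. Within the data shown here, the one single-place step measured, a number 35 percentage points lower from compound 1 to compound 2 (beyond the scatter), shows that replacing the hydrogen on the amine nitrogen weakens the effect beyond the scatter. Compound 4 `CCO/C=N/C1=C(C#N)C(c2ccc(Cl)cc2Cl)C2=C(CCCC2=O)N1c1ccc(S(N)(=O)=O)cc1` is not yet measured; it differs from compound 1 in that (a group of 5 heavy atoms (3 carbon, 1 nitrogen, 1 oxygen; no ring) in place of one nitrogen atom, on a double-bonded ring carbon). The step to compound 2 bears on this change, since it too removes the amine hydrogen; compound 3, which also lacks the free amino group, stands far lower still, though its change from compound 1 is not a single step. A drop in this assay is expected, a number 50 percentage points lower from compound 1 to compound 4 (beyond the scatter). Compound 4 is therefore estimated at 45%, within 20% to 75%.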

Compound 4, a percentage reported as activity, at one concentration (the size of the read-out at that concentration, not a potency): 40%
The estimate for compound 4 lay 5 percentage points above the measured number, within the range that was stated.
By their numbers in this assay, from the lowest: compound 3; then compound 4; then compound 2; then compound 1.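

In this assay the drop at this double-bonded ring carbon recurs with a second replacement of the amino group (a number 55 percentage points lower from compound 1 to compound 4 (beyond the scatter)). On the carbon with a double bond to nitrogen, ethoxy and 2,4-dinitrophenyl also separate (a number 20 percentage points higher from compound 3 to compound 4 (beyond the scatter)). The two acylated and ethoxy-bearing groups differ as well (a number 20 percentage points lower from compound 2 to compound 4 (beyond the scatter)), so the size of the loss follows the entering group, not only the departure of the amino group.

From the compounds shown here alone, whether methoxy or a longer alkoxy chain in place of ethoxy would move the value remains open. No measurement at hand gives a reason for these differences.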